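A few compounds are considered here, and "the series" means these few. Any claim that something is new, unique, unknown or untested is made for them only; others in the source may bear on it.

Compound 1 `CCCc1cccc(C[C@H](O)/C=C/[C@H]2CCC(=S)N2CCCCCCC(=O)O)c1`: 2000 nM
Compound 2 `O=C(O)CCCSCCN1C(=O)SC[C@@H]1/C=C/[C@@H](O)Cc1ccccc1`: 39 nM
Compound 3 `Cc1cccc(C[C@H](O)/C=C/[C@H]2CCC(=S)N2CCSCCCC(=O)O)c1`: 980 nM

In an assay on CHO cells for displacement of a labelled ligand from prostaglandin E2 receptor EP3 subtype (Mus musculus), read by scintillation counting, with a stated time of 60 min (a lower number here means a stronger inhibitor, a higher number a weaker inhibitor), compound 2 gives the lowest number of the three, and its gaps to compound 3 and to compound 1 both lie beyond the usual scatter. Compound 4 `CCc1cccc(C[C@H](O)/C=C/[C@H]2CSC(=O)N2CCSCCCC(=O)O)c1` has not been measured yet. It differs from compound 2 in one place only: ethyl in place of hydrogen on an aromatic carbon. Within the data shown here, no measured pair shows this change on its own on a shared core; compounds 1 and 3 carry other groups on that ring but rest on a different core, so their numbers are no direct guide. The step is expected to be small, within the scatter or only slightly beyond it, with no firm direction. Compound 4 is therefore estimated at 50 nM (range 15 nM to 200 nM), an expected step of a 1.3-fold higher number from compound 2 to compound 4 (0.11 log units; within the scatter).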

Compound 4, inhibition constant: 65 nM
For compound 4 the middle estimate is 1.3-fold (0.11 log units) below the measured one; low and high end bracket the measured number.
By their numbers in this assay, from the lowest: compounds 2 and 4 (each within the scatter of the next); then compound 3; then compound 1.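

Among these compounds, the step of a 1.7-fold higher number from compound 2 to compound 4 (0.22 log units; within the scatter) in this assay is the first direct reading of this change on a shared core. Compound 2 and compound 4 cannot be told apart here, so a position meta to a large group can carry ethyl in place of hydrogen while the number stays close to that of compound 2. The earlier compounds shown here could not show this, since those with groups on that ring rest on a different core. From the compounds shown here alone, whether a longer chain such as butyl, an amine or a carboxylic acid would fit there as well remains open. Nothing measured here explains the result.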